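Truncating an ester side chain on the spiro core

A few compounds are considered here, and "the series" means these few. Any claim that something is new, unique, unknown or untested is made for them only; others in the source may bear on it.

Measured compounds:
compound 1 `CC1(C)CC(OC(=O)CN2CN(c3ccccc3)C3(CCN(C(=O)c4ccc(C5CCCCC5)cc4)CC3)C2=O)CC(C)(C)N1` — 600 nM
compound 2 `COC(=O)CCNC(=O)CN1CN(c2ccccc2)C2(CCN(C(=O)c3ccc(C4CCCCC4)cc3)CC2)C1=O` — 12900 nM

Compound 2 carries the higher of the two numbers in an assay on HEK293 cells for displacement of a labelled ligand from NPC1-like intracellular cholesterol transporter 1 (Homo sapiens); on this read-out higher numbers stand for weaker inhibition and lower numbers for stronger inhibition: it gives 12900 nM, while compound 1 gives 600 nM. Going by the values given here, the only step between them, a 22-fold higher number from compound 1 to compound 2 (1.33 log units; beyond the scatter), shows how much the group on the amide-side carbonyl matters on the shared core.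

Compound 3 `O=C(CN1CN(c2ccccc2)C2(CCN(C(=O)c3ccc(C4CCCCC4)cc3)CC2)C1=O)NCO` takes the next step from compound 2: hydroxy in place of (methoxycarbonyl)methyl on a saturated chain carbon bound to an amide-type nitrogen. Put another way, the (2-(methoxycarbonyl)ethyl)amino chain becomes a (hydroxymethyl)amino group, so the ester is gone and a short hydroxyl-bearing chain remains.

Among the compounds with values here, no measured pair tests this exact change. The step from compound 1 to compound 2 only establishes that swapping what hangs on this carbonyl can move this assay by a large amount, and that the ester-bearing chain of compound 2 gives the weaker result. Since the ester is removed rather than replaced by the group of compound 1, no clear direction can be read from the data, and the expected step of a 1.2-fold higher number from compound 2 to compound 3 (0.07 log units; within the scatter) is put near zero with a broad range. Compound 3 is therefore estimated at 15000 nM, between 4000 nM and 50000 nM.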

Compound 3, half-maximal inhibitory concentration: 8300 nM
Compound 3: middle estimate off by 1.8-fold (0.26 log units), on the high side; measured number inside the range.
By their numbers in this assay, from the lowest: compound 1; then compounds 3 and 2 (each within the scatter of the next).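

On the carbonyl of the shared core, the change from a 2-(methoxycarbonyl)ethyl to a hydroxymethyl chain gives a step that stays within the scatter in this assay (a 1.6-fold lower number from compound 2 to compound 3 (0.19 log units; within the scatter)), so these two amide side chains cannot be told apart on this read-out. The ester at the end of the chain of compound 2 therefore does not account for its distance from compound 1: without that ester, the large gap remains (a 14-fold higher number from compound 1 to compound 3 (1.14 log units; beyond the scatter)) and lies beyond the scatter. No measurement offered here explains why the (2,2,6,6-tetramethylpiperidin-4-yl)oxy group stands apart from these two chains.

The compounds shown leave open whether that gap belongs to the tetramethylpiperidine part of the group or to the ester link joining it to the carbonyl, a question that a (2,2,6,6-tetramethylpiperidin-4-yl)amino group on the same carbon would separate. They also leave open whether a side chain ending in a carboxylic acid or a primary amine would stay level with compound 2 and compound 3 or move toward compound 1.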